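Changing the chain end of the weakest compound

A few compounds are considered here, and "the series" means these few. Any claim that something is new, unique, unknown or untested is made for them only; others in the source may bear on it.

Going by the values given here, in a functional assay on K562 cells (Homo sapiens) for antiproliferative activity, read by MTT assay, with a stated time of 48 h (on this read-out higher numbers stand for weaker inhibition and lower numbers for stronger inhibition), compound 2 `Cn1cc(C2=C(c3nn(CCCn4cccc4)c4ncccc34)C(=O)NC2=O)c2ccccc21` gives 21600 nM, the highest number of the three measured so far and so the weakest inhibition. Compound 1 `Cn1cc(C2=C(c3nn(CCCN4CCCCC4)c4ncccc34)C(=O)N(c3ccccc3)C2=O)c2ccccc21` gives 3790 nM and compound 3 `Cn1cc(C2=C(c3nn(CCCN4CCCCC4)c4ncccc34)C(=O)N(c3cccc4ccccc34)C2=O)c2ccccc21` gives 3180 nM, both beyond the scatter from compound 2.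

Compound 4 `Cn1cc(C2=C(c3nn(CCCO)c4ncccc34)C(=O)NC2=O)c2ccccc21` keeps everything in compound 2 except the end of the chain: hydroxy in place of 1H-pyrrol-1-yl on a saturated chain carbon, three bonds along the chain from an aromatic nitrogen. Put simply, hydroxy takes the place of 1H-pyrrol-1-yl on a saturated chain carbon, three bonds along the chain from an aromatic nitrogen, so that 3-(1H-pyrrol-1-yl)propyl becomes 3-hydroxypropyl.

The data offer little guidance for this swap. Among the compounds with values here, the only measured single-place step is a 1.2-fold lower number from compound 1 to compound 3 (0.08 log units; within the scatter), and it concerns the group on an amide-type nitrogen in a ring, not the chain end. Compounds 1 and 3 differ from compound 2 in more than one place, so their values cannot be credited to the chain end alone. Within the data shown here, no measured step isolates this change, so no shift beyond the scatter in this assay is expected, in either direction. The expected step is a 1.2-fold lower number from compound 2 to compound 4 (0.08 log units; within the scatter), an estimate that stays within the scatter. For compound 4 the estimated value is 18000 nM, with an expected range from 6000 nM to 50000 nM.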

Compound 4, half-maximal inhibitory concentration: 85800 nM
The estimate for compound 4 lay 4.8-fold (0.68 log units) below the measured number; measured number outside the range, above it.
By their numbers in this assay, from the lowest: compounds 3 and 1 (each within the scatter of the next); then compound 2; then compound 4.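

In this assay, the end of the chain turns out to matter: replacing 1H-pyrrol-1-yl with hydroxy gives a 4.0-fold higher number from compound 2 to compound 4 (0.60 log units; beyond the scatter) and so weaker inhibition of cell growth. The earlier step concerned only the group on an amide-type nitrogen in a ring and left this position untested, whereas compound 2 and compound 4 differ in this one place, so the shift belongs to this change alone. The numbers show that the outcome depends on the group at the end of the 3-carbon propyl chain, but no measurement here explains why the swap has this effect.

A single pair cannot show whether the ring of 1H-pyrrol-1-yl, the hydroxy group or some other difference between the two chain ends drives the shift, nor whether the same change would have a similar effect on a compound with a different group on the amide-type nitrogen. A methoxy group, a primary amine or a carboxylic acid at the chain end, or a hydroxy group on a longer chain, would each test this position further.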